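The source may report more compounds than this note shows. Statements on the series, on what has been measured and on what is new or still open speak of the compounds shown alone.

Measured compounds: compound 1 `COc1ccc(C(=O)C=CNc2cc(-c3ccccc3)nn2-c2ccccc2)cc1`, 1290 nM; compound 2 `CN1CCN(c2ccc(-c3c(C#N)c(-c4ccc(Cl)cc4)nc4c3c(-c3ccccc3)nn4-c3ccccc3)cc2)CC1`, 2710 nM; compound 3 `O=C(C=CNc1cc(-c2ccccc2)nn1-c1ccccc1)c1ccc(Cl)cc1`, 8070 nM, all in a functional assay on MCF7 cells (Homo sapiens) for inhibition, read by MTT assay, with a stated time of 48 h; a higher number here means a weaker inhibitor, a lower number a stronger inhibitor.

Compounds 1 and 3 share a core and differ in one place: methoxy in place of chloro on an aromatic carbon. That change gave a 6.3-fold lower number from compound 3 to compound 1 (0.80 log units; beyond the scatter). Compound 4 `COc1ccc(-c2nc3c(c(-c4ccccc4)nn3-c3ccccc3)c(-c3ccc(N4CCN(C)CC4)cc3)c2C#N)cc1` is not yet measured; it stands to compound 2 as compound 1 stands to compound 3: methoxy in place of chloro on an aromatic carbon. The place of the change is described in the same words for both pairs, so the change is the same, though the difference between the two cores is not broken down here. For compound 4 the expected step in this assay is a 2.3-fold lower number from compound 2 to compound 4 (0.35 log units; beyond the scatter), smaller than the earlier one because the only support for it, a 6.3-fold lower number from compound 3 to compound 1 (0.80 log units; beyond the scatter), comes from a different core. Compound 4 is therefore estimated at 1200 nM, with a range from 500 nM to 3000 nM.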

Compound 4, half-maximal inhibitory concentration: 2650 nM
Compound 4: the middle estimate sits 2.2-fold (0.34 log units) below what was measured; the range from low to high includes it.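

In this assay, the change from 4-chlorophenyl to 4-methoxyphenyl, carried to the second core, gave a 1.0-fold lower number from compound 2 to compound 4 (0.01 log units; within the scatter) and so did not repeat the step seen on the first core. The two steps differ: the same change on two cores in this assay, a 6.3-fold lower number (0.80 log units; beyond the scatter) from compound 3 to compound 1 and a 1.0-fold lower number (0.01 log units; within the scatter) from compound 2 to compound 4, 6.1-fold (0.79 log units) apart, beyond the scatter of two such steps. This shows that, for these two cores, a step measured on one did not predict the step on the other, but with a single pair on each core it does not show what in the cores accounts for the gap or which step is more typical of the series.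

The compounds shown leave open how a hydroxyl or an amine in the same place would read on either core. They also leave open which of the two steps a third core would follow.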